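The source may report more compounds than this note shows. Statements on the series, on what has been measured and on what is new or still open speak of the compounds shown alone.

Among the compounds with values here, compound 1 `COc1cc(-c2nn(-c3cccc(NC(=O)Nc4ccc(Cl)c(Cl)c4)c3)cc2-c2ccncc2)ccc1Cl` is one of three compounds measured in a functional assay on KM12 cells (Homo sapiens) for inhibition, read by sulforhodamine B assay, with a stated time of 48 h; on this read-out higher numbers stand for weaker inhibition of growth and lower numbers for stronger inhibition of growth. In this assay compound 1 gives 2770 nM, the second highest of the three numbers. Within the data shown here, its closest neighbour is compound 2 `O=C(Nc1cccc(-n2cc(-c3ccncc3)c(-c3ccc(Cl)c(O)c3)n2)c1)Nc1ccc(Cl)c(Cl)c1`, which keeps the shared core and the dichlorophenyl urea but carries a hydroxy in place of the methoxy; in this assay compound 2 gives 4470 nM, and the one step that is known directly, a 1.6-fold higher number from compound 1 to compound 2 (0.21 log units; within the scatter), stays within the scatter. Compound 3 `O=C(Nc1cccc(-n2cc(-c3ccncc3)c(-c3ccc(Cl)c(O)c3)n2)c1)Nc1cc(C(F)(F)F)cc(C(F)(F)F)c1` shares the hydroxy-bearing core of compound 2 and differs from it only in the urea aryl, a bis(trifluoromethyl)phenyl; in this assay compound 3 gives 1430 nM. Among the measured compounds shown here, no step between compound 2 and compound 3 is measured as such, so only their two values speak.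

Compound 4 `COc1cc(-c2nn(-c3cccc(NC(=O)Nc4ccc(Cl)c(C(F)(F)F)c4)c3)cc2-c2ccncc2)ccc1Cl` is not yet measured. It differs from compound 1 by trifluoromethyl in place of chloro on an aromatic carbon. The measured step from compound 1 to compound 2 does not touch this part of the molecule, so it bears little on the change. The pair of compound 2 and compound 3 shows that a urea aryl carrying trifluoromethyl is paired with a lower number than the dichlorophenyl. On that slender ground a modest lowering is expected, a 1.4-fold lower number from compound 1 to compound 4 (0.14 log units; within the scatter), and compound 4 is estimated at 2000 nM, within a range from 900 nM to 4500 nM.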

Compound 4, concentration for total growth inhibition: 3920 nM
Beside the measured number, compound 4's estimate is 2.0-fold (0.29 log units) below it, within the range that was stated.
By their numbers in this assay, from the lowest: compounds 3, 1, 4 and 2 (each within the scatter of the next, the first and the last beyond it).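

In this assay, the exchange of the 3,4-dichlorophenyl of compound 1 for the 4-chloro-3-(trifluoromethyl)phenyl of compound 4 reads as a 1.4-fold higher number from compound 1 to compound 4 (0.15 log units; within the scatter), so the two compounds cannot be told apart on this read-out. Within the data shown here, this is the first direct reading of trifluoromethyl in place of chloro at this position, on an aromatic carbon ortho to a chloro group and meta to a large group, with the rest of the molecule held the same. The clear gap between the printed values of compound 2 and compound 3, whose urea aryl groups differ as wholes, is not seen for this exchange alone, and no measurement at hand offers an explanation for the result.

The compounds shown leave open whether the same exchange would read alike on the hydroxy-bearing core of compound 2. They also do not tell how this position would respond to a group of another kind, such as a nitrile, an amine or a carboxylic acid, in place of the chloro of compound 1.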